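Chloro for methyl on two phenyl rings of the core

The compounds below may be only part of what the source reports. "The series", "measured", "known", "first", "only" and "open" are said of these compounds alone.

Measured compounds:
compound 1 `Cc1cccc(-n2nc(-c3ccccc3)c(C=O)c2/N=C/N(C)C)c1`: 31000 nM
compound 2 `CN(C)/C=N/c1c(C=O)c(-c2ccccc2)nn1-c1cccc(Cl)c1`: 6900 nM
compound 3 `Cc1ccc(-c2nn(-c3ccccc3)c(/N=C/N(C)C)c2C=O)cc1`: 11900 nM

All three numbers come from a functional assay on NCI-H661 cells (Homo sapiens) for inhibition, read by MTT assay, with a stated time of 72 h; a higher number here means a weaker inhibitor of growth, a lower number a stronger inhibitor of growth. Compound 2 sits at the low end of the set, and from compound 1 the move is a 4.5-fold lower number from compound 1 to compound 2 (0.65 log units; beyond the scatter), with the change (chloro in place of methyl on an aromatic carbon). Compound 3 and compound 2 lie within the scatter of each other, so no order between them is claimed; compound 3 stands beyond the scatter from compound 1, with the higher number at compound 1. The difference between the core of compound 1 and the core of compound 3 is not broken down here.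

Compound 4 `CN(C)/C=N/c1c(C=O)c(-c2ccc(Cl)cc2)nn1-c1ccccc1` is not yet measured. It differs from compound 3 by chloro in place of methyl on an aromatic carbon. This is the same kind of change as that from compound 1 to compound 2, but the place is not the same: there the chloro sits meta to a large group, here para to a large group, and on a different phenyl ring of the core. For the measured compounds named here, only one measured instance of the change exists, so the expectation rests on it alone. Because the earlier step was a 4.5-fold lower number from compound 1 to compound 2 (0.65 log units; beyond the scatter), a step of similar direction is expected, though kept somewhat smaller for the different place: the expected step is a 3.0-fold lower number from compound 3 to compound 4 (0.47 log units; beyond the scatter). In this assay compound 4 is expected to give 4000 nM, with a likely range from 1500 nM to 12000 nM.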

Compound 4, concentration for 50% growth inhibition: 8600 nM
Compound 4: middle estimate off by 2.2-fold (0.33 log units), on the low side; the range from low to high includes it.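

Carried to the core of compound 3, the change from 4-methylphenyl to 4-chlorophenyl gives a 1.4-fold lower number from compound 3 to compound 4 (0.14 log units; within the scatter) in this assay, so this pair cannot be put in any order. The size of the step therefore does not transfer from one core to the other in this assay, and a gain seen on one phenyl ring cannot be assumed on the other: the same change on two cores in this assay, a 4.5-fold lower number (0.65 log units; beyond the scatter) from compound 1 to compound 2 and a 1.4-fold lower number (0.14 log units; within the scatter) from compound 3 to compound 4, 3.2-fold (0.51 log units) apart, beyond the scatter of two such steps What remains unshown is the reason for the gap, since the two instances differ in the ring that carries the chloro as well as in its place, and two instances set no rule for any further core in the series.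

The compounds shown leave open whether a fluoro, methoxy or trifluoromethyl group on either phenyl ring would behave like the chloro, and whether an amine or a carboxylic acid at those places would shift the number in this assay. Also open, from the compounds shown here alone, is how the series would respond if the aldehyde carbonyl gave way to a nitrile, and whether either step would read the same on a cell line other than NCI-H661.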